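A few compounds are considered here, and "the series" means these few. Any claim that something is new, unique, unknown or untested is made for them only; others in the source may bear on it.

Compound 3 `COc1cc(/C=C/C(=O)OCc2c(-c3ccccc3)no[n+]2[O-])ccc1O` is measured in a functional assay on M4E cells (Homo sapiens) for cytotoxicity, read by resazurin assay, with a stated time of 72 h (on this read-out higher numbers stand for weaker inhibition and lower numbers for stronger inhibition), where compound 3 gives 3370 nM. Compound 2 `O=C(/C=C/c1ccc(O)c(O)c1)OCc1c(-c2ccccc2)no[n+]1[O-]` differs from it by a single change, (hydrogen in place of methyl on an oxygen on an aromatic ring), and in this assay compound 2 gives 12900 nM. That change made a step of a 3.8-fold higher number from compound 3 to compound 2 (0.58 log units; beyond the scatter).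

Compound 1 `COc1cc(/C=C/C(=O)OCCCO[N+](=O)[O-])ccc1OCCCO[N+](=O)[O-]` belongs to a different core; how its core differs from that of compound 3 is not broken down here. In this assay compound 1 gives > 50000 nM, which is a limit of the assay rather than a number, as shown by the limit of > 50000 nM in this assay, at which 1 of the 3 values shown sits.

Compound 4 `O=C(/C=C/c1ccc(OCCCO[N+](=O)[O-])c(O)c1)OCCCO[N+](=O)[O-]` has not yet been measured. It differs from compound 1 by hydrogen in place of methyl on an oxygen on an aromatic ring, the same change as from compound 3 to compound 2. From compound 1 to compound 4 a step that the limit leaves unreadable from compound 1 to compound 4 is expected, resting on the step of a 3.8-fold higher number from compound 3 to compound 2 (0.58 log units; beyond the scatter), which moved the number upward. Compound 4 is therefore estimated at 150000 nM, with a range from 50000 nM to 500000 nM, and most likely the assay will again report only a limit.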

Compound 4, half-maximal inhibitory concentration: 14100 nM
The estimate for compound 4 lay 11-fold (1.03 log units) above the measured number, outside the stated range (below it).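

The same swap of methoxy to hydroxy gave an at least 3.5-fold lower number from compound 1 to compound 4 (0.54 log units; beyond the scatter) in this assay, so its effect did not carry from one core to the other, not even in direction: the same change on two cores in this assay, a 3.8-fold higher number (0.58 log units; beyond the scatter) from compound 3 to compound 2 and an at least 3.5-fold lower number (0.54 log units; beyond the scatter) from compound 1 to compound 4, at least 13-fold (1.13 log units) apart, beyond the scatter of two such steps.
Compound 1 stands at a limit of the assay and not at a number, so the step gives only a minimum size: the limit of > 50000 nM in this assay, at which 1 of the 4 values shown sits.
Two cores show that this change can reverse direction, but they do not show why it does so or how it would behave on any third core.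

Left open is how an ethoxy group or an amine in place of the methoxy would read on either core in this assay.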